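A methylsulfonyl compound in a series of limits

The source may report more compounds than this note shows. Statements on the series, on what has been measured and on what is new or still open speak of the compounds shown alone.

Compound 1 `Cn1c(-c2ccccc2)nnc1S(C)(=O)=O`: > 200 mg/kg, a limit
Compound 2 `CSc1nnc(-c2ccc(C)cc2)n1C`: > 100 mg/kg, a limit
Compound 3 `Cc1ccc(-c2nnc([S+](C)[O-])n2C)cc1`: > 200 mg/kg, a limit

In a functional assay on the whole organism for antagonist activity, with Mus musculus as the target, in the maximal electroshock model (a higher number here means that more compound is needed for the effect, a lower number that less compound is needed), compound 3 gives only a limit, > 200 mg/kg, and so stands at the limit of > 200 mg/kg in this assay, at which 2 of the 3 values shown sit. The change to compound 4 `Cc1ccc(-c2nnc(S(C)(=O)=O)n2C)cc1` is a group of 4 heavy atoms (1 carbon, 2 oxygen, 1 sulfur; no ring) in place of a group of 3 heavy atoms (1 carbon, 1 oxygen, 1 sulfur; no ring), on an aromatic carbon. The entering methylsulfonyl sits on a five-membered aromatic ring with 3 nitrogen, between two ring nitrogen atoms. Going by the values given here, the one measured step that bears on this change is a step that the two limits leave unreadable from compound 2 to compound 3, and it offers no size to carry over. Compound 1, which also carries methylsulfonyl, is likewise only a limit, > 200 mg/kg. No change beyond the scatter is therefore expected, and the estimated step is a number no higher from compound 3 to compound 4 (the limit leaves the size open). Compound 4 is expected at 200 mg/kg, within an estimated range of 80 mg/kg to 400 mg/kg.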

Compound 4, dose for half-maximal effect: > 200 mg/kg
Compound 4: no number, only a limit; the forecaster's own chance of this, stated with the estimate: 70%; the middle value sits exactly at the limit.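

In this assay compound 4 gives only a limit, so its steps from compound 1, compound 2 and compound 3 cannot be read. The compounds shown leave open whether methylsulfonyl and methylsulfanyl differ at all on the shared core.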